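The compounds below may be only part of what the source reports. "The series", "measured", "known", "first", "only" and "open" are said of these compounds alone.

Of the compounds shown here, three sharing one core have been tested in a functional assay on the whole organism (strain albino) with Mus musculus as the target, with a stated time of 4 h; a higher number here means that more compound is needed for the effect, a lower number that less compound is needed. Compound 1 `COc1ccc(Nc2nnc(Nc3nc(-c4ccc(Cl)cc4)cs3)s2)cc1` gives 300 mg/kg in this assay. Compound 2 `Cc1ccccc1Nc1nnc(Nc2nc(-c3ccc([N+](=O)[O-])cc3)cs2)s1` gives 300 mg/kg, and compound 3 `COc1ccccc1Nc1nnc(Nc2nc(-c3ccc([N+](=O)[O-])cc3)cs2)s1` gives 300 mg/kg. The only single-point step among them, no change at the digits printed from compound 2 to compound 3 (within the scatter), stays within the scatter, and compound 3 stands level with compound 1 and compound 2 on every figure shown.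

Compound 4 `COc1ccc(Nc2nnc(Nc3nc(-c4ccc([N+](=O)[O-])cc4)cs3)s2)cc1` has not yet been measured. It holds the same atoms as compound 3, joined differently: 4-methoxyphenyl in place of 2-methoxyphenyl on a nitrogen on an aromatic ring. The 2-methoxyphenyl group leaves and a 4-methoxyphenyl group enters, on a nitrogen on an aromatic ring.

Among the measured compounds shown here, no measured step swaps these two groups directly. For the measured compounds named here, what bears on it is indirect: compound 1 carries the 4-methoxyphenyl group and shows the same figure as compound 3, and the single measured step, from compound 2 to compound 3, was flat. With every value in hand lying level, the expectation for compound 4 is a step of no change at the digits printed from compound 3 to compound 4 (within the scatter) that stays within the scatter. Compound 4 is therefore estimated at 300 mg/kg in this assay, with a likely range from 150 mg/kg to 600 mg/kg.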

Compound 4, minimum effective dose: 100 mg/kg
The estimate for compound 4 lay 3.0-fold (0.48 log units) above the measured number; measured number below the stated range.
By their numbers in this assay, from the lowest: compound 4; then compounds 1, 2 and 3 (each within the scatter of the next).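

In this assay the swap of 2-methoxyphenyl for 4-methoxyphenyl on the nitrogen gives a real step (a 3.0-fold lower number from compound 3 to compound 4 (0.48 log units; beyond the scatter)), so with the same atoms present, how they are joined matters at this place, something the flat earlier step could not show. The change from 2-methylphenyl to 4-methoxyphenyl at the same place gives a matching step (a 3.0-fold lower number from compound 2 to compound 4 (0.48 log units; beyond the scatter)), so the two groups that stood level there both need more compound than 4-methoxyphenyl does. The other end of the molecule counts as well: with 4-methoxyphenyl held fixed, nitro in place of chloro on an aromatic carbon also lowers the number (a 3.0-fold lower number from compound 1 to compound 4 (0.48 log units; beyond the scatter)), and of these four compounds only compound 4 carries both 4-methoxyphenyl and nitro.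

The compounds shown leave open whether 4-ethoxyphenyl or 4-aminophenyl on that nitrogen would keep this lower number, and whether a nitrile in place of the nitro would do the same. They also give no measurement that explains why either change lowers the dose needed.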